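Notes on replacing the amino side chain with hydroxyethyl

A few compounds are considered here, and "the series" means these few. Any claim that something is new, unique, unknown or untested is made for them only; others in the source may bear on it.

Values in a functional assay on MDA-MB-435 cells (Homo sapiens) for cytotoxicity, read by MTT assay, with a stated time of 72 h (a higher number here means a weaker inhibitor, a lower number a stronger inhibitor), are as follows.
- compound 1 `CS(=O)(=O)Oc1c(C(=O)NCc2ccc(F)cc2)nc(Br)c2cccnc12` gives > 20000 nM as a limit of the assay
- compound 2 `NCCCNc1c(C(=O)NCc2ccc(F)cc2)nc(Br)c2cccnc12` gives 5000 nM
- compound 3 `N[C@H]1CC[C@H](Nc2c(C(=O)NCc3ccc(F)cc3)nc(Br)c3cccnc23)CC1` gives 6000 nM

Among the compounds with values here, compound 3 stands level with compound 2 (a 1.2-fold higher number from compound 2 to compound 3 (0.08 log units; within the scatter)), and the only other value is a limit. Compound 4 `O=C(NCc1ccc(F)cc1)c1nc(Br)c2cccnc2c1NCCO` has 2-hydroxyethyl in place of 4-aminocyclohexyl on a nitrogen on an aromatic ring. Within the data shown here, no measured step makes this exchange. The nearest evidence is the entry of the two amino chains into compound 2 and compound 3 (an at least 4.0-fold lower number from compound 1 to compound 2 (0.60 log units; beyond the scatter) and an at least 3.3-fold lower number from compound 1 to compound 3 (0.52 log units; beyond the scatter)), and the new chain carries no amine. A modest move to a higher number is therefore expected, with a 1.8-fold higher number from compound 3 to compound 4 (0.26 log units; within the scatter) as the estimated step in this assay for this series. Compound 4 is estimated at 11000 nM (range 5000 nM to 20000 nM) for now.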

Compound 4, half-maximal inhibitory concentration: > 20000 nM
Compound 4 was reported as a limit; the forecaster's own chance of this, stated with the estimate: 35%; at least 1.8-fold (0.25 log units) between middle value and limit.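

In this assay, 2-hydroxyethyl in place of 4-aminocyclohexyl gives an at least 3.3-fold higher number from compound 3 to compound 4 (0.52 log units; beyond the scatter), and hydroxy in place of aminomethyl on the chain gives an at least 4.0-fold higher number from compound 2 to compound 4 (0.60 log units; beyond the scatter). Compound 4 gives > 20000 nM, which is a limit of the assay. On this nitrogen, then, the chains ending in an amine in compound 2 and compound 3 give readable values and the chain ending in hydroxy does not, while the step from compound 1 to compound 4 cannot be read because both sit at the limit: the limit of > 20000 nM in this assay, at which 2 of the 4 values shown sit.

On these data alone, it remains open whether the terminal amine or the chain length decides this, which a 2-aminoethyl chain and a 3-hydroxypropyl chain could separate.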